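This account rests on a few compounds, and the source may have more. Where it says the series, first, only, none or still open, it means among the compounds named here.

Compound 2 `CCOC(=O)c1cc2ccc(OCc3ccccc3)cc2oc1=O` is the strongest inhibitor among the three compounds measured in an in vitro assay on BTI-TN-5B1-4 cells for inhibition of Amine oxidase [flavin-containing] B (Homo sapiens), read by fluorescence, with a stated time of 15 min (a higher number here means a weaker inhibitor, a lower number a stronger inhibitor), where compound 2 gives 7.01 nM. Compound 1 `CCOC(=O)c1cc2ccc(N(CC)CC)cc2oc1=O` gives 45500 nM, and compound 3 `CCOC(=O)c1cc2ccc(OCc3cccc(Cl)c3)cc2oc1=O` gives 61.2 nM. Exchanging the diethylamino group for a benzyloxy group produced a 6500-fold lower number from compound 1 to compound 2 (3.81 log units; beyond the scatter), while placing a chloro group on the benzyloxy group produced an 8.7-fold higher number from compound 2 to compound 3 (0.94 log units; beyond the scatter). Compound 4 `CCOC(=O)c1cc2ccc(OCc3ccc(C(C)(C)C)cc3)cc2oc1=O` differs from compound 2 by tert-butyl in place of hydrogen on an aromatic carbon. Within the data shown here, the chloro step is the one comparable change, a substituent added to the benzyloxy group, and it was modest and weakened inhibition, so a modest weakening is expected here as well, a 14-fold higher number from compound 2 to compound 4 (1.15 log units; beyond the scatter). Compound 4 is therefore estimated at 100 nM, with a range of 15 nM to 700 nM.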

Compound 4, half-maximal inhibitory concentration: 3750 nM
For compound 4 the middle estimate is 38-fold (1.57 log units) below the measured one, outside the stated range (above it).
By their numbers in this assay, from the lowest: compound 2; then compound 3; then compound 4; then compound 1.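

Tert-butyl on this aromatic carbon, para to a large group, gives a 530-fold higher number from compound 2 to compound 4 (2.73 log units; beyond the scatter) in this assay and that is far more than the chloro step of an 8.7-fold higher number from compound 2 to compound 3 (0.94 log units; beyond the scatter) on the same benzyloxy group. Adding a substituent to the benzyloxy group is therefore not always a modest change, and the size of the weakening differs with the group, its place, or both. Nothing measured here explains this weakening. Still open, going by these compounds, is how methyl or methoxy would compare at this same place, and whether chloro there would behave like tert-butyl.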